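Chloro addition on the benzamide of the shared core

The source may report more compounds than this note shows. Statements on the series, on what has been measured and on what is new or still open speak of the compounds shown alone.

Measured so far:
compound 1, `COc1cc(-c2nn(-c3cccc(NC(=O)Nc4cc(C(F)(F)F)cc(C(F)(F)F)c4)c3)cc2-c2ccncc2)ccc1Cl`: in a functional assay on RPMI-8226 cells (Homo sapiens) for inhibition, read by sulforhodamine B assay, with a stated time of 48 h (a higher number here means that more compound is tolerated, a lower number that less compound is tolerated), compound 1 gives only the limit > 50000 nM
compound 2, `COc1cc(-c2nn(-c3cccc(NC(=O)c4cccc(C(F)(F)F)c4)c3)cc2-c2ccncc2)ccc1Cl`: in this assay compound 2 gives only the limit > 50000 nM

Compound 2 stands at the edge of what this assay can report, as the figure is a limit and not a number. Within the data shown here, the same holds for both values shown, (the limit of > 50000 nM in this assay, at which 2 of the 2 values shown sit), so no measured step exists between compound 1 and compound 2, and nothing is known about how this series moves in this assay.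

Compound 3, `COc1cc(-c2nn(-c3cccc(NC(=O)c4ccc(Cl)c(C(F)(F)F)c4)c3)cc2-c2ccncc2)ccc1Cl`, differs from compound 2 by chloro in place of hydrogen on an aromatic carbon, ortho to a trifluoromethyl group, para to a large group. Among the measured compounds shown here, with no measured step to lean on, no change beyond the usual scatter is expected, and the step from compound 2 to compound 3 is estimated at a step that the limit leaves unreadable from compound 2 to compound 3. Compound 3 is accordingly expected near 60000 nM, within 20000 nM to 150000 nM, most likely again reported only as a limit.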

Compound 3, concentration lethal to 50% of the cells: > 32500 nM
Compound 3 gave a limit, no number (the forecaster's own chance of this, stated with the estimate: 75%); the middle value lies beyond the limit too.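

In this assay compound 3 gives only the limit > 32500 nM. Among these compounds, compound 2 also gives only a limit, so no step from compound 2 to compound 3 can be read. Still open, as far as these compounds go, is whether chloro in place of hydrogen on an aromatic carbon shifts the read-out at all, and whether any of compound 1, compound 2 or compound 3 would give an actual number in this assay.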